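A Methoxy Added to Compound 2

A few compounds are considered here, and "the series" means these few. Any claim that something is new, unique, unknown or untested is made for them only; others in the source may bear on it.

Compound 1 `COc1c(C)cnc(C[S+]([O-])c2nc3cc(OC(F)F)ccc3[nH]2)c1C`: 0.2 h
Compound 2 `COc1ccnc(C[S+]([O-])c2nc3cc(OC(F)F)ccc3[nH]2)c1C`: 0.0833 h

Both numbers come from an ADME assay, at pH 3; on this read-out lower numbers stand for a shorter-lived compound and higher numbers for a longer-lived compound. Of these two compounds, compound 2 stands lowest, at 0.0833 h. Compound 3 `COc1cc2[nH]c([S+]([O-])Cc3nccc(OC)c3C)nc2cc1OC(F)F` has not yet been measured. It differs from compound 2 in one place: methoxy in place of hydrogen on an aromatic carbon. This is methoxy in place of hydrogen on an aromatic carbon, ortho to a difluoromethoxy group.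

Within the data shown here, no measured step shows this change. Among the measured compounds shown here, the only step available is a 2.4-fold lower number from compound 1 to compound 2 (0.38 log units; beyond the scatter), which involves methyl rather than methoxy and at best hints at a plausible size. With so little evidence, no clear direction can be expected in this assay, and no shift beyond the scatter is predicted. The expected step is a 1.2-fold lower number from compound 2 to compound 3 (0.08 log units; within the scatter). For compound 3 the estimated half-life is 0.07 h, with an expected range from 0.03 h to 0.16 h.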

Compound 3, half-life: 0.1 h
Beside the measured number, compound 3's estimate is 1.4-fold (0.15 log units) below it, and the stated range covers the measured number.
By their numbers in this assay, from the lowest: compounds 2, 3 and 1 (each within the scatter of the next, the first and the last beyond it).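

In this assay, placing methoxy on this aromatic carbon, ortho to a difluoromethoxy group, gives a 1.2-fold higher number from compound 2 to compound 3 (0.08 log units; within the scatter), so this change leaves the half-life indistinguishable from that of the unsubstituted position. Among these compounds, the earlier step changed methyl to hydrogen on a different aromatic carbon, so this is the first reading from the six-membered aromatic ring of carbon only, and it shows that a methoxy group can be placed here without a shift beyond the scatter. No measured evidence is available to explain this result.

On these data alone, it remains open whether an amine, a carboxylic acid or a longer alkoxy chain at this position would shift the half-life beyond the scatter. As far as these compounds go, it is also open whether methoxy here would have the same small effect in compound 1, which carries the extra methyl group.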